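This account rests on a few compounds, and the source may have more. Where it says the series, first, only, none or still open, it means among the compounds named here.

Among the compounds with values here, compound 2 `CCOC(=O)N1CCC(Sc2c[nH]c3ccc(Br)cc23)CC1` gives 27.3 mg/kg in a functional assay on the whole organism with Mus musculus as the target, in the hot plate test (a lower number here means that less compound is needed, a higher number that more compound is needed for the effect), the higher of the two numbers known so far. Compound 1 `CC(=O)N1CCC(Sc2c[nH]c3ccc(Cl)cc23)CC1` gives 3.8 mg/kg in this assay, a clearly lower number, but compound 1 and compound 2 differ in two places, so no single step can be read from that pair. Compound 3 `CON1CCC(Sc2c[nH]c3ccc(Br)cc23)CC1` differs from compound 2 in one place only: methoxy in place of ethoxycarbonyl on an amine nitrogen in a ring. Within the data shown here, no measured pair shows this change, so the expected step of a 1.2-fold lower number from compound 2 to compound 3 (0.09 log units; within the scatter) is none beyond the scatter, in either direction. Compound 3 is estimated at 22 mg/kg, with a range from 7 mg/kg to 70 mg/kg.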

Compound 3, dose for half-maximal effect: 3.2 mg/kg
The estimate for compound 3 lay 6.9-fold (0.84 log units) above the measured number; the measured number lies below the stated range.
By their numbers in this assay, from the lowest: compounds 3 and 1 (each within the scatter of the next); then compound 2.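

The group on this amine nitrogen clearly matters in this assay: methoxy in place of ethoxycarbonyl gives an 8.5-fold lower number from compound 2 to compound 3 (0.93 log units; beyond the scatter), well beyond the scatter. Within the data shown here, this is the first single change that can be read at this position, and it shows that replacing ethoxycarbonyl with the smaller methoxy, which has no double bond, means less compound is needed. Nothing available explains this drop.

From the compounds shown here alone, whether a plain methyl, a longer alkoxy chain or a free amine on this nitrogen would give a number like that of compound 3 stays open. So does whether this step holds on any other core.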